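The compounds below may be only part of what the source reports. "The series", "measured", "known", "first", "only" and "open" are said of these compounds alone.

In an ADME assay on the whole organism (Rattus norvegicus, strain Sprague-Dawley) for pharmacokinetics, read by LC-MS, with a stated time of 24 h, at a dose of 10 mg/kg by the oral route (on this read-out higher numbers stand for higher oral bioavailability and lower numbers for lower oral bioavailability), two compounds have been measured: compound 1 `CCC(=O)Nc1cc(Nc2ncc(Br)c(Nc3ccc4cc[nH]c4c3)n2)c(OC)cc1N1CCN(C)CC1` gives 53.7%; compound 2 `C=CC(=O)Nc1cc(Nc2ncc(Br)c(Nc3ccc4ccn(C)c4c3)n2)c(OC)cc1N1CCN(C)CC1` gives 52.3%.

Compound 2 stands next to compound 1, the two values lying within the usual scatter of each other, so no ranking between them can be drawn. Compound 3 `C=CC(=O)Nc1cc(Nc2ncc(Br)c(Nc3ccc4c(c3)CCC4)n2)c(OC)cc1N1CCN(C)CC1` has not yet been measured. It differs from compound 2 in one place: 2,3-dihydro-1H-inden-5-yl in place of 1-methyl-1H-indol-6-yl on a nitrogen on an aromatic ring. For the measured compounds named here, no measured pair shows this kind of change, so a step of about a number 4.3 percentage points lower from compound 2 to compound 3 (within the scatter) is expected, not beyond the scatter. Compound 3 is estimated at 48%, between 30% and 66%.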

Compound 3, oral bioavailability: 35.6%
Compound 3: the middle estimate sits 12.4 percentage points above what was measured, and the stated range covers the measured number.
By their numbers in this assay, from the lowest: compound 3; then compounds 2 and 1 (each within the scatter of the next).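

In this assay, putting 2,3-dihydro-1H-inden-5-yl in place of 1-methyl-1H-indol-6-yl on a nitrogen on an aromatic ring brings a number 16.7 percentage points lower from compound 2 to compound 3 (beyond the scatter), so the group at this place can move oral bioavailability, which the earlier two compounds, differing in more than one place, could not show. The change removes the ring nitrogen and makes the five-membered ring non-aromatic, and no measurement at hand tells which of these matters or why the number falls.

From the compounds shown here alone, whether a plain phenyl or a pyridinyl group on this nitrogen would stand nearer compound 2 or compound 3 remains open. So does the outcome of adding an amine or a carboxylic acid to the ring.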